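Amino for nitro on two related sulfone cores

The source may report more compounds than this note shows. Statements on the series, on what has been measured and on what is new or still open speak of the compounds shown alone.

Compound 1, `COc1ccccc1/C=C/S(=O)(=O)Cc1ccc(OC)c([N+](=O)[O-])c1`, gives 20000 nM in a functional assay on K562 cells (Homo sapiens) for cytotoxicity, read by trypan blue exclusion, with a stated time of 96 h; a higher number here means a weaker inhibitor, a lower number a stronger inhibitor.
Compound 2, `COc1ccc(CS(=O)(=O)/C=C/c2ccccc2OC)cc1N`, gives 7500 nM in this assay.
Compound 3, `COc1ccc(CS(=O)(=O)/C=C/c2c(OC)cc(O)cc2OC)cc1[N+](=O)[O-]`, gives 5000 nM in this assay.

Compound 4, `COc1ccc(CS(=O)(=O)/C=C/c2c(OC)cc(O)cc2OC)cc1N`, has not yet been measured in this assay. It is related to compound 3 by one change: amino in place of nitro on an aromatic carbon. The same change relates compound 1 to compound 2: amino in place of nitro on an aromatic carbon. The surroundings of the place agree word for word in both pairs, so this is the same change, and it occurs twice among the four compounds. The difference between the core of compound 1 and the core of compound 3 is not broken down here. In this assay the first pair shows a 2.7-fold lower number from compound 1 to compound 2 (0.43 log units; beyond the scatter). Compound 3 lies within the scatter of compound 2 and beyond it from compound 1. Compound 4 is expected to show a 2.5-fold lower number from compound 3 to compound 4 (0.40 log units; beyond the scatter), an expectation resting on a 2.7-fold lower number from compound 1 to compound 2 (0.43 log units; beyond the scatter), while a single precedent on a different core leaves room for a smaller or larger step. Compound 4 is therefore estimated at 2000 nM in this assay, with a likely range from 900 nM to 5000 nM.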

Compound 4, half-maximal inhibitory concentration: 300 nM
The estimate for compound 4 lay 6.7-fold (0.82 log units) above the measured number, and the stated range ends above it.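

In this assay, amino in place of nitro on an aromatic carbon gives a lower number on both cores, and on the core of compound 3 the result is a 17-fold lower number from compound 3 to compound 4 (1.22 log units; beyond the scatter). Among these compounds, the direction of the change carries over from one core to the other, but its size does not: the same change on two cores in this assay, a 2.7-fold lower number (0.43 log units; beyond the scatter) from compound 1 to compound 2 and a 17-fold lower number (1.22 log units; beyond the scatter) from compound 3 to compound 4, 6.3-fold (0.80 log units) apart, beyond the scatter of two such steps With only one pair on each core, this does not show which part of the difference between the two cores goes with the larger step, and it gives no rule for how large the step would be on any further core.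

Going by these compounds, it remains open whether a group other than amino at the same place, such as an acetamide or a dimethylamino group, would also give a step of this size on the core of compound 3. Also open, on these data alone, is how the change would behave on a core carrying only some of the features that separate the core of compound 3 from that of compound 1.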